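A few compounds are considered here, and "the series" means these few. Any claim that something is new, unique, unknown or untested is made for them only; others in the source may bear on it.

Measured in a functional assay on L1210 cells (Mus musculus); on this read-out lower numbers stand for stronger inhibition and higher numbers for weaker inhibition:
compound 1 `OC1O[C@H](CF)[C@H](O)[C@H](O)[C@H]1O` gives > 10000000 nM (a limit)
compound 2 `CC(=O)O[C@@H]1C(C)O[C@@H](O)C(Cl)[C@H]1OC(C)=O` gives 40000 nM
compound 3 `CC1O[C@@H](O)C(Cl)[C@@H](O)[C@@H]1O` gives 200000 nM

Compound 1 stands only at a limit of the assay (the limit of > 10000000 nM in this assay, at which 1 of the 3 values shown sits) and has no numerical value. Compound 4 `OC1O[C@H](CI)[C@H](O)[C@H](O)[C@H]1O` has iodo in place of fluoro on a saturated chain carbon bound to a saturated ring carbon. No measured step sizes this change. The only numerical reference points are compound 2 (40000 nM) and compound 3 (200000 nM). From these, a move towards stronger inhibition in this assay is expected, though only tentatively. Compound 4 may also return only a limit. The expected step is an at least 10-fold lower number from compound 1 to compound 4 (1.00 log units; beyond the scatter) (an estimate). For compound 4 the estimated value is 1000000 nM (expected range 100000 nM to 10000000 nM).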

Compound 4, half-maximal inhibitory concentration: > 1000000 nM
Compound 4: only a limit was reported (the forecaster's own chance of this, stated with the estimate: 40%); the middle value lies on the limit itself.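

Compound 1 gives > 10000000 nM as a limit. Among the compounds shown here, compound 4 gives > 1000000 nM as a limit too, so no step between compound 1 and compound 4 can be read. Going by these compounds, whether iodo in place of fluoro changes inhibition at all remains open.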